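This account rests on a few compounds, and the source may have more. Where it says the series, first, only, none or still open, it means among the compounds named here.

Measured compounds in a physicochemical assay for acid dissociation:
Compound 1 `COc1cccc(CNCCCNc2ccnc3cc(Oc4ccc(Cl)cc4)ccc23)c1O` gives 9.28.
Compound 2 `COc1cccc(CNCCCNc2ccnc3cc(Oc4ccccc4)ccc23)c1O` gives 9.28.
Compound 3 `COc1cccc(CNCCCNc2ccnc3cc(Cc4ccc(C#N)cc4)ccc23)c1O` gives 9.47.

Compound 3 holds the highest of the three numbers, yet its gaps to the others are within the scatter, as a number 0.19 log units higher from compound 1 to compound 3 (within the scatter) and a number 0.19 log units higher from compound 2 to compound 3 (within the scatter) show, and likewise no change at the digits printed from compound 1 to compound 2 (within the scatter). Compound 4 `COc1cccc(CNCCCNc2ccnc3cc(Cc4cc(C)cc(C)c4)ccc23)c1O` is not yet measured; it differs from compound 3 by 3,5-dimethylphenyl in place of 4-cyanophenyl on a saturated chain carbon bound to an aromatic carbon. All three measured steps altered the group at this same outer part of the molecule and none moved the number beyond the scatter, so the step from compound 3 to compound 4 is expected to be a number 0.02 log units lower from compound 3 to compound 4 (within the scatter), essentially none. Compound 4 is therefore estimated at 9.45, between 9.15 and 9.75.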

Compound 4, acid dissociation constant: 9.47
The estimate for compound 4 lay 0.02 log units below the measured number, and the stated range covers the measured number.
By their numbers in this assay, from the lowest: compounds 1, 2, 3 and 4 (each within the scatter of the next).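

In this assay, replacing 4-cyanophenyl with 3,5-dimethylphenyl on a saturated chain carbon bound to an aromatic carbon gives no change at the digits printed from compound 3 to compound 4 (within the scatter), so exchanging the nitrile-bearing ring for one of carbon only, with the link kept, leaves the read-out unmoved. Placing 3,5-dimethylbenzyl on the aromatic carbon instead of phenoxy gives a number 0.19 log units higher from compound 2 to compound 4 (within the scatter), and instead of 4-chlorophenoxy gives a number 0.19 log units higher from compound 1 to compound 4 (within the scatter). No measurement is available to explain this result. As far as these compounds go, whether an amine or a carboxylic acid on the outer ring, or a longer chain at the saturated carbon, would move the number beyond the scatter remains open.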